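The source may report more compounds than this note shows. Statements on the series, on what has been measured and on what is new or still open speak of the compounds shown alone.

Of the compounds shown here, two have been measured in an assay on mitochondria for inhibition of HSP60/HSP10 (Homo sapiens); on this read-out lower numbers stand for stronger inhibition and higher numbers for weaker inhibition. Compound 1 `O=S(=O)(Nc1ccc(-c2nc3cc(NS(=O)(=O)c4ccc(Cl)s4)ccc3o2)cc1)c1ccc(Cl)s1` gives 6500 nM in this assay. Compound 2 `COc1ccc(S(=O)(=O)Nc2ccc3oc(-c4ccc(NS(=O)(=O)c5cc(F)ccc5OC)cc4)nc3c2)cc1` shares the same core with two sulfonamide-linked aryl groups, but for compound 2 this assay records only a limit, > 100000 nM, not a number; this is the limit of > 100000 nM in this assay, at which 1 of the 2 values shown sits. Of the two values shown, compound 2 thus stands at the weak end, while compound 1 sits at a measured value.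

Compound 3 `COc1ccc(S(=O)(=O)Nc2ccc3oc(-c4ccc(NC(=O)c5cccc(C)c5[N+](=O)[O-])cc4)nc3c2)cc1` keeps one side of compound 2 unchanged and alters the other: a group of 12 heavy atoms (8 carbon, 1 nitrogen, 3 oxygen; one six-membered aromatic ring of carbon only) in place of a group of 12 heavy atoms (7 carbon, 3 oxygen, 1 fluorine, 1 sulfur; one six-membered aromatic ring of carbon only), on a nitrogen on an aromatic ring. Going by the values given here, no measured pair shows this change, so the expectation rests on compound 2 alone, whose result is only a limit. The step expected an at least 1.6-fold lower number from compound 2 to compound 3 (0.22 log units; that floor lies within the scatter) is toward somewhat stronger inhibition, but it is uncertain, and a limit for compound 3 would not surprise. Compound 3 is estimated at 60000 nM, with a range expected from 10000 nM to 200000 nM.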

Compound 3, half-maximal inhibitory concentration: 72000 nM
For compound 3 the middle estimate is 1.2-fold (0.08 log units) below the measured one; measured number inside the range.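

In this assay compound 3 gives 72000 nM, so this nitrogen on an aromatic ring now has a measured number with the (3-methyl-2-nitrophenyl)carbonyl group on it, while the other side of the molecule stays as in compound 2. Replacing the group that leaves compound 2 amounts to an at least 1.3-fold lower number from compound 2 to compound 3 (0.14 log units; that floor lies within the scatter), which means that this pair alone does not establish stronger inhibition, even though the group that enters matches the one that leaves in heavy atoms, hydrogen-bond donors and hydrogen-bond acceptors. The real size of the step stays unknown because compound 2 is recorded only as a limit: the limit of > 100000 nM in this assay, at which 1 of the 3 values shown sits.

The compounds shown do not separate the contribution of the nitro group from that of the methyl group, or the carbonyl link from the ring it carries. Going by these compounds, how a plain acetyl group, or a ring bearing a carboxylic acid, would read on this nitrogen in this assay also stays open, as does whether the (3-methyl-2-nitrophenyl)carbonyl group would give a similar result with the other side of compound 1.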